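A chlorine shift on a weak growth inhibitor

The compounds below may be only part of what the source reports. "The series", "measured", "known", "first", "only" and "open" are said of these compounds alone.

In a functional assay on NCI-H520 cells (Homo sapiens) (a higher number here means a weaker inhibitor of growth, a lower number a stronger inhibitor of growth), compound 1 `O=S(=O)(/C=C/c1ccc(Cl)c(Cl)c1)Cc1ccc(Nc2ncnc3ccccc23)cc1` gives 32000 nM as its reading. Compound 2 `O=S(=O)(/C=C/c1ccc(F)cc1Cl)Cc1ccc(Nc2ncnc3ccccc23)cc1` gives 100000 nM in this assay as its reading. Compound 3 `O=S(=O)(/C=C/c1ccc(Cl)c(Cl)c1)Cc1ccc(Nc2ncnc3ccc(Br)cc23)cc1` stands at > 100000 nM in this assay and this is a limit of the assay, not a number.

Compound 4 `O=S(=O)(/C=C/c1ccc(Cl)cc1Cl)Cc1ccc(Nc2ncnc3ccc(Br)cc23)cc1` differs from compound 3 as 2,4-dichlorophenyl in place of 3,4-dichlorophenyl on a double-bonded chain carbon bound to a double-bonded chain carbon shows, with 2,4-dichlorophenyl in place of 3,4-dichlorophenyl on a double-bonded chain carbon bound to a double-bonded chain carbon.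

Within the data shown here, two measured steps bear on this. Among the measured compounds shown here, the only change measured at that place is a 3.1-fold higher number from compound 1 to compound 2 (0.49 log units; beyond the scatter) and it is modest but beyond the scatter, though it involves a different incoming group and was measured without the bromo. The bromo itself brings an at least 3.1-fold higher number from compound 1 to compound 3 (0.49 log units; beyond the scatter) and that step is at least modest. Compound 4 keeps this bromo. Both steps lead to weaker growth inhibition, and neither shows what the 2,4-dichlorophenyl group does on its own.

Resting on those two steps, the expected result is a number no higher from compound 3 to compound 4 (the limit leaves the size open) and no shift beyond the scatter in either direction. For compound 4 the estimated value is 100000 nM with an expected range from 32000 nM to 200000 nM and a report as a limit alone is quite likely.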

Compound 4, concentration for 50% growth inhibition: 8000 nM
Estimate against measurement, compound 4: 13-fold (1.10 log units) above; the whole stated range lies above it.
By their numbers in this assay, from the lowest: compound 4; then compound 1; then compound 2.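

The swap of 3,4-dichlorophenyl for 2,4-dichlorophenyl changes no atom count, only how the same atoms are joined, yet in this assay it brings an at least 12-fold lower number from compound 3 to compound 4 (1.09 log units; beyond the scatter), so at this place on the chain the arrangement of the two chlorines alone can decide the reading. Among these compounds, the only earlier step at this place, a 3.1-fold higher number from compound 1 to compound 2 (0.49 log units; beyond the scatter), ran the other way, with 2-chloro-4-fluorophenyl and without the bromo, so the two steps together show that changes here can move growth inhibition in either direction. Compound 3 stands at > 100000 nM, which is a limit of the assay and not a number, so the true size of the new step stays unknown and only its direction and its lower bound are secure: the limit of > 100000 nM in this assay, at which 1 of the 4 values shown sits.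

As far as these compounds go, what the 2,4-dichlorophenyl group does on the shared core without the bromo remains open, so it cannot yet be said whether the bromo takes any part in this gain. Also open, from the compounds shown here alone, is whether an amine or a carboxylic acid on this aromatic ring, or a longer chain in place of the double-bonded one, would keep a reading as low as that of compound 4.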